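The compounds below may be only part of what the source reports. "The series", "measured", "known", "first", "only" and "open" are said of these compounds alone.

Series notes. Compound 1 `COc1cc(Nc2ncc(C(F)(F)F)c(N3Cc4cccc(N(C)S(C)(=O)=O)c4C3)n2)c(OC)cc1Cl` is assessed in a functional assay on U-87MG ATCC cells for antiproliferative activity against U-87 MG (Homo sapiens), read by spectrophotometry, with a stated time of 2 days (on this read-out higher numbers stand for weaker inhibition of growth and lower numbers for stronger inhibition of growth), where compound 1 gives 6200 nM, the lowest of the two numbers recorded so far. Compound 2 `CN(c1cccc2c1CN(c1nc(Nc3ccc(Nc4ccccc4)cc3)ncc1C(F)(F)F)C2)S(C)(=O)=O` gives 29800 nM, a higher number than compound 1 and beyond the scatter. Compound 3 `COc1cc(Nc2ncc(C(F)(F)F)c(N3Cc4cccc(N(C)S(C)(=O)=O)c4C3)n2)cc(C(F)(F)F)c1` is not yet measured; it differs from compound 1 by 3-methoxy-5-(trifluoromethyl)phenyl in place of 4-chloro-2,5-dimethoxyphenyl on a nitrogen on an aromatic ring. Among the compounds with values here, no measured step covers this kind of change, so the expectation rests only on the value of compound 1 and the structural swap. A modest weakening in this assay is expected, a 1.6-fold higher number from compound 1 to compound 3 (0.21 log units; within the scatter), though the uncertainty is wide. Compound 3 is estimated at 10000 nM, with a range from 3000 nM to 40000 nM.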

Compound 3, concentration for 50% growth inhibition: > 30000 nM
Compound 3: only a limit was reported; the forecaster's own chance of this, stated with the estimate: 20%; middle value at least 3.0-fold (0.47 log units) from the limit.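

Within the data shown here, the aryl group on a nitrogen on an aromatic ring is the first place where a change can be read in this assay: 3-methoxy-5-(trifluoromethyl)phenyl in place of 4-chloro-2,5-dimethoxyphenyl gives an at least 4.8-fold higher number from compound 1 to compound 3 (0.68 log units; beyond the scatter). The reading for compound 3 is a limit and not a number, so the full size of this step stays unknown: the limit of > 30000 nM in this assay, at which 1 of the 3 values shown sits.

The swap alters the chlorine, a methoxy and the trifluoromethyl together, and the compounds shown do not separate them. Also open, on these data alone, is how an aryl group carrying an amine or a carboxylic acid would read in this assay at this place.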